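Oxime ester shortening in a trimethoxyphenyl naphthyl series

The compounds below may be only part of what the source reports. "The series", "measured", "known", "first", "only" and "open" are said of these compounds alone.

Compound 1 `CCOC(=O)CCO/N=C(/c1ccc(OC)c(OC)c1OC)c1cccc2ccccc12` is the reference point of this small set. In a functional assay on HCT-116 cells (Homo sapiens) for inhibition, read by sulforhodamine B assay, with a stated time of 48 h (on this read-out lower numbers stand for stronger inhibition and higher numbers for weaker inhibition), compound 1 gives 10000 nM, the only numerical result among the three measured compounds. Compound 2 `CCOC(=O)C(C)C(O)(c1ccc(OC)c(OC)c1OC)c1cccc2ccccc12` returns only a limit of the assay, > 20000 nM. Compound 3 `COc1ccc(C(O)(Cc2ccc(F)cc2)c2cccc3ccccc23)c(OC)c1OC` likewise returns only a limit, > 20000 nM. For the measured compounds named here, the one step that can be drawn between measured compounds, a step that the two limits leave unreadable from compound 2 to compound 3, is therefore unreadable, since both ends sit at the limit of > 20000 nM in this assay, at which 2 of the 3 values shown sit.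

Compound 4 `COc1ccc(/C(=N/OC(C)=O)c2cccc3ccccc23)c(OC)c1OC` differs from compound 1 by acetyl in place of 2-(ethoxycarbonyl)ethyl on an oxygen, a change on the oxime oxygen that keeps the shared core and the oxime itself. Going by the values given here, none of the measured steps touches this position, so no measured step bears on it; the shortening from 2-(ethoxycarbonyl)ethyl to acetyl is judged only from compound 1 and its value of 10000 nM. No step beyond the usual scatter is expected in this assay. The step is estimated as no change at the digits printed from compound 1 to compound 4 (within the scatter). Compound 4 is accordingly expected to give 10000 nM, with a likely range from 4000 nM to 25000 nM.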

Compound 4, half-maximal inhibitory concentration: 4980 nM
Beside the measured number, compound 4's estimate is 2.0-fold (0.30 log units) above it, within the range that was stated.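

In this assay, the oxime oxygen now has a readable step: acetyl in place of 2-(ethoxycarbonyl)ethyl gives a 2.0-fold lower number from compound 1 to compound 4 (0.30 log units; within the scatter). Across this pair, the size of the group on the oxime oxygen can differ, from 2-(ethoxycarbonyl)ethyl down to acetyl, with no step beyond the scatter. The 2-(ethoxycarbonyl)ethoxy chain as a whole is therefore not needed to keep a numerical result at this position, although the pair offers no ranking of the two groups.

As far as these compounds go, whether an amine, a carboxylic acid or a chain longer than 2-(ethoxycarbonyl)ethyl on the oxime oxygen would give a step beyond the scatter remains open. Compound 2 and compound 3 both stand at a limit, so the step between them cannot be read: the limit of > 20000 nM in this assay, at which 2 of the 4 values shown sit.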